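The source may hold more compounds than are shown below. What is called first, only, known or untested is meant among the compounds shown, and "the series" means these compounds.

Compound 1 `O=C(c1cc(Cl)ccn1)N1CCN(c2nccc(Oc3cc(Cl)cc(Cl)c3)n2)CC1`: 16700 nM
Compound 2 `O=C([C@H]1Cc2ccccc2N1)N1CCN(c2nccc(Oc3cc(Cl)cc(Cl)c3)n2)CC1`: > 50000 nM

Among the compounds with values here, in a functional assay on MDA-MB-231 cells (Homo sapiens) for antiproliferative activity, read by MTT assay, with a stated time of 24 h (on this read-out higher numbers stand for weaker inhibition and lower numbers for stronger inhibition), compound 1 gives 16700 nM, the only exact number so far. The value for compound 2, > 50000 nM, is a limit of the assay.

Compound 3 `O=S(=O)(c1ccccc1)N1CCN(c2nccc(Oc3cc(Cl)cc(Cl)c3)n2)CC1`, not yet measured, carries phenylsulfonyl in place of (4-chloropyridin-2-yl)carbonyl on an amine nitrogen in a ring. Within the data shown here, one measured step bears on this, an at least 2.9-fold higher number from compound 1 to compound 2 (0.47 log units; beyond the scatter), and it replaces another group in the same part of the molecule. That single step points towards weaker inhibition, so a modest rise is expected in this assay. The estimated step is a 1.7-fold higher number from compound 1 to compound 3 (0.22 log units; within the scatter). For compound 3 the expected value is 28000 nM, with an estimated range of 11000 nM to 70000 nM.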

Compound 3, half-maximal inhibitory concentration: > 50000 nM
Compound 3 ended at the assay's limit (the forecaster's own chance of this, stated with the estimate: 35%); middle value at least 1.7-fold (0.25 log units) away from the limit.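

In this assay, phenylsulfonyl on this amine nitrogen gives an at least 2.9-fold higher number from compound 1 to compound 3 (0.47 log units; beyond the scatter). So a second, quite different replacement for (4-chloropyridin-2-yl)carbonyl, this time with a sulfonyl link and a carbon-only aromatic ring, also fails to match compound 1. The value for compound 3 is a limit, so the step gives only a minimum size: the limit of > 50000 nM in this assay, at which 2 of the 3 values shown sit.

The compounds shown leave open whether the carbonyl link or the 4-chloropyridin-2-yl ring matters more. A benzoyl group at this position, which keeps the carbonyl on a carbon-only ring, would help separate the two.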